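A few compounds are considered here, and "the series" means these few. Any claim that something is new, unique, unknown or untested is made for them only; others in the source may bear on it.

Three close relatives of one shared core have been tested in an ADME assay on CCRF-HSB-2 cells (Homo sapiens) for cytotoxicity, with a stated time of 7 days; on this read-out higher numbers stand for lower toxicity in this test and lower numbers for higher toxicity in this test. Compound 1, `CC(C)CSc1nc(N)nc2c1ncn2/C=C1/CC1(CO)CO`, carries an isobutylsulfanyl group on an aromatic carbon, and in this assay compound 1 gives 60000 nM. Compound 2, `CCOc1nc(N)nc2c1ncn2/C=C1/CC1(CO)CO`, has ethoxy in place of isobutylsulfanyl on an aromatic carbon; only a limit of the assay is known for it, and compound 2 gives > 20000 nM. Compound 3, `COCCOc1nc(N)nc2c1ncn2/C=C1/CC1(CO)CO`, has 2-methoxyethoxy in place of isobutylsulfanyl on an aromatic carbon; here too only a limit is known, and compound 3 gives > 20000 nM. Compound 3 thus stands at the limit of > 20000 nM in this assay, at which 2 of the 3 values shown sit, and no number places it against the others. The steps a step that the limit leaves unreadable from compound 1 to compound 2, a step that the limit leaves unreadable from compound 1 to compound 3 and a step that the two limits leave unreadable from compound 2 to compound 3 are all left unreadable by these limits.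

The step now followed leads to compound 4, `CSc1nc(N)nc2c1ncn2/C=C1/CC1(CO)CO`, and is methylsulfanyl in place of 2-methoxyethoxy on an aromatic carbon. For the measured compounds named here, no measured step bears on it directly, as every step from compound 3 is unreadable. Going by the values given here, the one number in the set is that of compound 1, whose isobutylsulfanyl group is the nearer relative of methylsulfanyl, and compound 1 gives 60000 nM. Compound 4 is therefore expected to show low toxicity in this assay. Compound 4 is estimated at 50000 nM, between 15000 nM and 150000 nM. The expected step is a step that the limit leaves unreadable from compound 3 to compound 4, a step that the limit on compound 3 leaves unreadable in practice.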

Compound 4, half-maximal cytotoxic concentration: > 100000 nM
Compound 4: no number, only a limit (the forecaster's own chance of this, stated with the estimate: 50%); middle value at least 2.0-fold (0.30 log units) from the limit.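

For the compounds shown here, compound 4 is known only as a limit in this assay: the limit of > 100000 nM in this assay, at which 1 of the 4 values shown sits. Changing isobutylsulfanyl to methylsulfanyl gives the first readable step at this aromatic carbon, an at least 1.6-fold higher number from compound 1 to compound 4 (0.22 log units; that floor lies within the scatter), although this floor does not establish a change beyond ordinary repeat variation. What it does show is that the shorter sulfur-linked group gave no sign of a lower number than compound 1, while the steps from compound 2 and compound 3 to compound 4 cannot be read, so the methylsulfanyl group cannot be placed against ethoxy or 2-methoxyethoxy.

The compounds shown leave open whether the sulfur-linked and oxygen-linked groups differ at all in this test, and how far the number for compound 4 lies from its limit. They also leave open how an amine or a longer sulfur-linked chain, such as n-hexylsulfanyl, at the same aromatic carbon would read in this assay.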